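The compounds below may be only part of what the source reports. "The series", "measured", "known", "first", "only" and "open" are said of these compounds alone.

Measured so far:
compound 1, `CCOC(=O)C1=C(C)N(c2ccccc2)C=CC1c1ccccc1`, -37.1%
compound 2, `CCOC(=O)C1=C(C)N(c2ccc(C)cc2)C=CC1c1ccccc1`, -38.4%
compound 3, `CCOC(=O)C1=C(C)N(c2ccc(F)cc2)C=CC1c1ccccc1`, -35.8%

All three compounds share one core and differ only in a single substituent on the aromatic ring attached to the nitrogen. In a functional assay for inhibition, using microsomes, tested at 200 ug/mL (a lower number here means a stronger effect, a higher number a weaker effect of the compound at the concentration tested), compound 1 gives -37.1%, compound 2 gives -38.4% and compound 3 gives -35.8%. Compound 3 holds the highest of the three numbers, but every step among them is small: a number 1.3 percentage points lower from compound 1 to compound 2 (within the scatter), a number 1.3 percentage points higher from compound 1 to compound 3 (within the scatter) and a number 2.6 percentage points higher from compound 2 to compound 3 (within the scatter). None of these stands out from the noise of repeated measurements, so the three compounds cannot be ranked against one another.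

Compound 4, `CCOC(=O)C1=C(C)N(c2ccc(Cl)cc2)C=CC1c1ccccc1`, is the next member of the series. Its structure differs from compound 3 in one place: chloro in place of fluoro on an aromatic carbon. The closest guide is the pair of steps that placed a fluoro on this same aromatic carbon, a number 1.3 percentage points higher from compound 1 to compound 3 (within the scatter) and a number 2.6 percentage points higher from compound 2 to compound 3 (within the scatter), both of them within the scatter. Swapping hydrogen for methyl at the same place, a number 1.3 percentage points lower from compound 1 to compound 2 (within the scatter), was equally unremarkable. Given that three different groups at this position left this assay essentially unchanged, the expectation for the chloro is another step of no real size: a number 0.7 percentage points lower from compound 3 to compound 4 (within the scatter) is the estimated change. Compound 4 is therefore expected to give about -36.5%, with a likely range from -48% to -25%.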

Compound 4, a percentage reported as activity, at one concentration (the size of the read-out at that concentration, not a potency): -34.4%
Compound 4: the middle estimate sits 2.1 percentage points below what was measured, and the stated range covers the measured number.
By their numbers in this assay, from the lowest: compounds 2, 1, 3 and 4 (each within the scatter of the next).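

Chloro is now a fourth group at this place on the aromatic ring, para to a large group, and in this assay it behaves like the other three: it gives a number 1.4 percentage points higher from compound 3 to compound 4 (within the scatter) when it replaces fluoro, a number 2.7 percentage points higher from compound 1 to compound 4 (within the scatter) when it replaces hydrogen and a number 4 percentage points higher from compound 2 to compound 4 (within the scatter) when it replaces methyl. Among these compounds, these comparisons cover every group now available at this place, so even the change from methyl to chloro, the largest step so far, cannot be told apart from repeat-to-repeat variation, and the four compounds remain unranked, with no compound going against this flat picture. Nothing available explains this insensitivity to the group at this place, so it stands as an observation only.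

From the compounds shown here alone, what remains open is whether a quite different group here, such as an amine, a carboxylic acid or a longer chain, would move the read-out beyond the scatter. The compounds shown also leave open how much the rest of the shared core matters, for instance whether replacing the ethyl ester with an amide would change the result.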